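The source may report more compounds than this note shows. Statements on the series, on what has been measured and on what is new or still open speak of the compounds shown alone.

Measured so far:
Compound 1 `Cc1ccc(-c2ccnc(C(=O)Nc3ccc(Oc4ccnc5[nH]ccc45)c(F)c3)n2)cc1` gives 1150 nM in a functional assay on A549 cells (Homo sapiens) for cytotoxicity, read by MTT assay, with a stated time of 72 h; a lower number here means a stronger inhibitor, a higher number a weaker inhibitor.
Compound 2 `O=C(Nc1ccc(Oc2ccnc3[nH]ccc23)c(F)c1)c1nccc(-c2cccc(Cl)c2)n1` gives 450 nM in this assay.

Among the measured compounds shown here, compound 2 holds the lower of the two numbers; the single measured step, a 2.6-fold lower number from compound 1 to compound 2 (0.41 log units; beyond the scatter), is the only one at this position. Compound 3 `O=C(Nc1ccc(Oc2ccnc3[nH]ccc23)c(F)c1)c1nccc(-c2ccc([N+](=O)[O-])cc2)n1` carries 4-nitrophenyl in place of 3-chlorophenyl on an aromatic carbon. For the measured compounds named here, no measured step replaces a halogen-bearing ring with a nitro-bearing one, so the one step at this position gives only the scale to expect. Compound 3 is expected at 650 nM, range 250 nM to 1700 nM. That estimate means a 1.4-fold higher number from compound 2 to compound 3 (0.16 log units; within the scatter), a step not clearly beyond the scatter.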

Compound 3, half-maximal inhibitory concentration: 4470 nM
For compound 3 the middle estimate is 6.9-fold (0.84 log units) below the measured one, outside the stated range (above it).
By their numbers in this assay, from the lowest: compound 2; then compound 1; then compound 3.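

The phenyl substituent at this position can move the number much further than the first step suggested: 4-nitrophenyl in place of 3-chlorophenyl gives a 9.9-fold higher number from compound 2 to compound 3 (1.00 log units; beyond the scatter) and nitro in place of methyl gives a 3.9-fold higher number from compound 1 to compound 3 (0.59 log units; beyond the scatter) in the same direction. Compound 3 therefore has the highest number of the three, and the substituent change can weaken as well as strengthen. Nothing available bears on the reason for this result.

The compounds shown leave open whether the nitro group itself or its place on the phenyl ring accounts for the change. On these data alone, how an amine or a carboxylic acid on that phenyl ring would read also remains open.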